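The source may hold more compounds than are shown below. What is called first, only, known or untested is meant among the compounds shown, and "the series" means these compounds.

Measured so far:
- compound 1 `CN1CCN(CCCN(C[C@H]2Cc3ccccc3CN2C)[C@H]2CCCc3cccnc32)CC1`: 536 nM
- compound 2 `CCN1CCN(CCCN(C[C@H]2Cc3ccccc3CN2)[C@H]2CCCc3cccnc32)CC1`: 33 nM
- compound 3 `c1cnc2c(c1)CN[C@H](CN(CCCN1CCNCC1)[C@H]1CCCc3cccnc31)C2`: 2640 nM

In a functional assay on CCRF-CEM cells for antagonist activity at C-X-C chemokine receptor type 4 (Homo sapiens), read by calcium flux, with stated times of 25 min and 90 s (a higher number here means a weaker inhibitor, a lower number a stronger inhibitor), compound 2 carries the lowest number of the three; the nearest is compound 1 with 536 nM and the furthest compound 3 with 2640 nM, both gaps beyond the scatter. Compound 4 `c1ccc2c(c1)CN[C@@H](CN(CCCCN1CCNCC1)[C@H]1CCCc3cccnc31)C2` has not been measured in this assay. It differs from compound 2 by (piperazin-1-yl)methyl in place of 4-ethylpiperazin-1-yl on a saturated chain carbon, three bonds along the chain from an amine nitrogen. For the measured compounds named here, no pair of measured compounds isolates this change, so the expected step from compound 2 to compound 4 rests on the whole set, where compound 2 stands apart from the others; a move upward beyond the scatter is expected, a 4.5-fold higher number from compound 2 to compound 4 (0.66 log units; beyond the scatter). Compound 4 is estimated at 150 nM, within 40 nM to 600 nM.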

Compound 4, half-maximal inhibitory concentration: 66 nM
Compound 4: the middle estimate sits 2.3-fold (0.36 log units) above what was measured, and the stated range covers the measured number.
By their numbers in this assay, from the lowest: compounds 2 and 4 (each within the scatter of the next); then compound 1; then compound 3.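

In this assay the exchange of 3-(4-ethylpiperazin-1-yl)propyl for 4-(piperazin-1-yl)butyl gives a 2.0-fold higher number from compound 2 to compound 4 (0.30 log units; within the scatter) and so keeps compound 4 level with compound 2. At this position, then, the added hydrogen-bond donor and the longer chain together leave the read-out within the scatter. Nothing on hand explains this result.

As far as these compounds go, the step joins two edits, the ethyl group and the chain length, so their separate contributions stay open. From the compounds shown here alone, also open in this assay is how a morpholine or a dimethylamino group would read at the chain end.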